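A New Group on the Sulfonyl Sulfur

The compounds below may be only part of what the source reports. "The series", "measured", "known", "first", "only" and "open" are said of these compounds alone.

In an ADME assay on microsomes from liver (Homo sapiens) for pharmacokinetics, read by LC-MS, with a stated time of 60 min, tested at 1 uM (on this read-out lower numbers stand for slow clearance and higher numbers for fast clearance), compound 1 `Nc1ccc(CNC(=O)Nc2ccc(S(=O)(=O)c3ccccc3)cc2)cn1` gives 5 mL/min/kg and compound 2 `O=C(NCc1cnccn1)Nc1ccc(S(=O)(=O)c2ccccc2)cc1` gives 5 mL/min/kg. Compound 3 `O=C(NCc1cccnc1)Nc1ccc(S(=O)(=O)N2C3CCC2COC3)cc1` reads 8 mL/min/kg, which lies within the scatter of both other values, so the three cannot be ranked. The next structure is compound 4 `N[C@H]1CC[C@H](NS(=O)(=O)c2ccc(NC(=O)NCc3cccnc3)cc2)CC1`, and the change is a group of 8 heavy atoms (6 carbon, 2 nitrogen; one six-membered non-aromatic ring of carbon only) in place of a group of 8 heavy atoms (6 carbon, 1 nitrogen, 1 oxygen; one five-membered non-aromatic ring with 1 hetero atom, one six-membered non-aromatic ring with 2 hetero atoms), on a sulfonyl sulfur. Here (4-aminocyclohexyl)amino takes the place of a group with no common name, on a sulfonyl sulfur.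

Within the data shown here, only one measured step bears on this series: no change at the digits printed from compound 1 to compound 2 (within the scatter). That step lies elsewhere in the molecule and leaves the sulfonyl sulfur untouched, so it offers only indirect guidance. Among the measured compounds shown here, no measured step tests (4-aminocyclohexyl)amino, and the new group could still move the number. Even so, compound 1 and compound 2 differ from compound 3 in the group on that sulfur, and compound 3 at 8 mL/min/kg stays within the scatter of their values. On that limited evidence, no shift beyond the scatter is expected in this assay, and the estimated change is a 1.3-fold lower number from compound 3 to compound 4 (0.12 log units; within the scatter). For compound 4 the expected clearance is 6 mL/min/kg, with an estimated range of 3 mL/min/kg to 13 mL/min/kg.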

Compound 4, clearance: 5 mL/min/kg
For compound 4 the middle estimate is 1.2-fold (0.08 log units) above the measured one; low and high end bracket the measured number.
By their numbers in this assay, from the lowest: compounds 1, 2, 4 and 3 (each within the scatter of the next).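

In this assay, among these compounds, the first measured exchange on the sulfonyl sulfur gives a 1.6-fold lower number from compound 3 to compound 4 (0.20 log units; within the scatter) and so does not separate the two groups beyond the scatter. The group with no common name, with its five-membered and six-membered non-aromatic rings, gives way to (4-aminocyclohexyl)amino, with one six-membered ring of carbon only, and the reading stays within the scatter even though the entering group has 2 hydrogen-bond donors where the leaving group has 0. Within this single pair, then, the sulfonyl sulfur has accepted two quite different groups of 8 heavy atoms without a change that can be told from repeat measurement, and nothing measured here offers an explanation for that.

The compounds shown leave open whether the amine on the cyclohexyl ring matters at all, as plain cyclohexylamino or a carboxylic acid in its place would show, and whether the stereoisomer with the other arrangement at the 2 defined stereocentres reads the same. They also leave open whether a much smaller group on the sulfonyl sulfur, such as dimethylamino, or a longer chain there would move the clearance beyond the scatter.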